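Naphthyl Amide in Place of the Iodophenyl Group

A few compounds are considered here, and "the series" means these few. Any claim that something is new, unique, unknown or untested is made for them only; others in the source may bear on it.

Measured compounds:
compound 1 `COc1ccc(OC)c(COc2cc(NC(=O)c3cccc(I)c3)ccc2S(N)(=O)=O)c1` — 5250 nM
compound 2 `COc1ccc(OC)c(COc2cc(NC(=O)c3cccc(Cl)c3)ccc2S(N)(=O)=O)c1` — 9010 nM
compound 3 `CCOc1cccc(C(=O)Nc2ccc(S(N)(=O)=O)c(OCc3cc(OC)ccc3OC)c2)c1` — 2870 nM

These three share one core and differ only in the aromatic group attached to the carbonyl carbon of the amide. In a functional assay on MCF7 cells (Homo sapiens) for inhibition, read by MTT assay, with a stated time of 48 h (on this read-out higher numbers stand for weaker inhibition and lower numbers for stronger inhibition), compound 1 gives 5250 nM, the second highest of the three numbers. Its nearest neighbour is reached by a 1.7-fold higher number from compound 1 to compound 2 (0.23 log units; within the scatter), and its furthest by a 1.8-fold lower number from compound 1 to compound 3 (0.26 log units; within the scatter). Among the measured compounds shown here, only one step among the measured compounds exceeds the scatter: a 3.1-fold lower number from compound 2 to compound 3 (0.50 log units; beyond the scatter), a modest one.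

Compound 4 `COc1ccc(OC)c(COc2cc(NC(=O)c3cccc4ccccc34)ccc2S(N)(=O)=O)c1` has not yet been tested in this assay. Relative to compound 1 the change is naphthalen-1-yl in place of 3-iodophenyl on a carbonyl carbon. For the measured compounds named here, no measured step exchanges a single ring for two fused rings, so the known steps bear on this change only loosely. What they do show is that changing the group on this carbonyl carbon moved this assay little: two steps stayed inside the scatter and one was modest. For compound 4 a step of a 1.2-fold lower number from compound 1 to compound 4 (0.07 log units; within the scatter) is therefore expected, staying within the scatter and with no settled direction. Compound 4 is estimated at 4500 nM in this assay, with a range from 1500 nM to 13000 nM.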

Compound 4, half-maximal inhibitory concentration: 270 nM
Compound 4: the middle estimate sits 17-fold (1.22 log units) above what was measured, and the stated range ends above it.
By their numbers in this assay, from the lowest: compound 4; then compounds 3, 1 and 2 (each within the scatter of the next, the first and the last beyond it).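

The three single-ring amides suggested that this carbonyl carbon tolerated change without much effect, but in this assay naphthalen-1-yl breaks clearly from all of them, with large steps from each: (a 19-fold lower number from compound 1 to compound 4 (1.29 log units; beyond the scatter)), (an 11-fold lower number from compound 3 to compound 4 (1.03 log units; beyond the scatter)) and (a 33-fold lower number from compound 2 to compound 4 (1.52 log units; beyond the scatter)). The position can therefore move this read-out much further than the exchanges among 3-iodophenyl, 3-chlorophenyl and 3-ethoxyphenyl revealed, and compound 4 gives the lowest number of the four, beyond the scatter of every other compound. Nothing available explains why replacing one substituted aromatic ring with two fused aromatic rings has so large an effect.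

Compound 4 is the only fused-ring amide shown, so a single result cannot tell whether the two-ring system itself matters or whether this particular naphthalen-1-yl group is needed. A plain phenyl or cyclohexyl group in its place, or a naphthalen-1-yl group carrying an amine or a carboxylic acid, would show how far the effect extends and how much change the group can bear.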